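The source may report more compounds than this note shows. Statements on the series, on what has been measured and on what is new or still open speak of the compounds shown alone.

Working notes on the series. All three measured compounds share a core carrying a trimethoxyphenyl arm on one side and a variable aryl group on the other: compound 1 `COc1cc(/C=C2\CCC/C(=C\c3ccccc3F)C2=O)cc(OC)c1OC`, compound 2 `COc1cc(/C=C2\CCC/C(=C\c3ccc(F)c(F)c3)C2=O)cc(OC)c1OC` and compound 3 `COc1cc(/C=C2\CCC/C(=C\c3ccc(O)c(Cl)c3)C2=O)cc(OC)c1OC`. In a functional assay on RKO cells (Homo sapiens) for antiproliferative activity, read by MTT assay, with a stated time of 72 h (a lower number here means a stronger inhibitor, a higher number a weaker inhibitor), compound 1 gives 1500 nM, compound 2 gives 2200 nM and compound 3 gives 700 nM. Compound 2 thus holds the highest of the three numbers, with compound 1 nearest to it and compound 3 furthest away.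

The step to the unmeasured compound 4 `COc1ccccc1/C=C1\CCC/C(=C\c2cc(OC)c(OC)c(OC)c2)C1=O` is 2-methoxyphenyl in place of 3,4-difluorophenyl on a double-bonded chain carbon bound to a double-bonded ring carbon. Going by the values given here, two measured steps bear on it. Adding a second fluorine and shifting the pattern gave a 1.5-fold higher number from compound 1 to compound 2 (0.17 log units; within the scatter), so fluorine count on this ring matters little here. Exchanging the difluorophenyl for a chloro-hydroxy pattern gave a 3.1-fold lower number from compound 2 to compound 3 (0.50 log units; beyond the scatter), a modest improvement. Among the compounds with values here, no measured step carries a methoxy on this ring, so the expectation rests on these two. A modest step toward a lower number, or none beyond the scatter, is expected in this assay, and the estimated step is a 1.7-fold lower number from compound 2 to compound 4 (0.23 log units; within the scatter). For compound 4 the expected value is 1300 nM, with a range from 500 nM to 3500 nM.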

Compound 4, half-maximal inhibitory concentration: 1200 nM
Beside the measured number, compound 4's estimate is 1.1-fold (0.03 log units) above it; low and high end bracket the measured number.
By their numbers in this assay, from the lowest: compounds 3, 4, 1 and 2 (each within the scatter of the next, the first and the last beyond it).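

In this assay, going by these compounds alone, the result gives the first reading of a methoxy on this aryl ring: methoxy in place of fluoro on an aromatic carbon gives a 1.3-fold lower number from compound 1 to compound 4 (0.10 log units; within the scatter), so this exchange shows no change that can be told from the scatter. The 2-methoxyphenyl group also stays within the scatter of both 3,4-difluorophenyl, with a 1.8-fold lower number from compound 2 to compound 4 (0.26 log units; within the scatter), and 3-chloro-4-hydroxyphenyl, with a 1.7-fold higher number from compound 3 to compound 4 (0.23 log units; within the scatter). Within the data shown here, compound 4 therefore sits within the scatter of two compounds that are themselves set apart by a 3.1-fold lower number from compound 2 to compound 3 (0.50 log units; beyond the scatter), a link the earlier compounds could not show.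

Still open, as far as these compounds go, is how this place on the double-bonded chain carbon responds to a longer ethoxy chain, an amine or a carboxylic acid on the aryl ring. No measurement in hand accounts for any of these steps.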